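Series notes: the amine-ring substituent, compound 2 toward compound 3

The source may hold more compounds than are shown below. What is called first, only, known or untested is meant among the compounds shown, and "the series" means these compounds.

Among the measured compounds shown here, compound 2 `CCN1CCN(CC(=O)Nc2ccc(-c3nc(-c4ccccc4)c(-c4ccccc4)n3C)cc2)CC1` gives 80 ug/mL in a functional assay on MCF7 cells (Homo sapiens) for cytotoxicity, read by MTT assay, with a stated time of 24 h (on this read-out lower numbers stand for stronger inhibition and higher numbers for weaker inhibition), the higher of the two numbers measured so far; the nearest is compound 1 `Cn1c(-c2ccc(NC(=O)CSc3nc4cc(Cl)ccc4o3)cc2)nc(-c2ccccc2)c1-c1ccccc1` with 21.7 ug/mL, and the only measured step, a 3.7-fold higher number from compound 1 to compound 2 (0.57 log units; beyond the scatter), separates them. Compound 3 `CN(C)/C=C/N1CCN(CC(=O)Nc2ccc(-c3nc(-c4ccccc4)c(-c4ccccc4)n3C)cc2)CC1` has not been measured. It differs from compound 2 by 2-(dimethylamino)ethenyl in place of ethyl on an amine nitrogen in a ring. For the measured compounds named here, the one measured step concerns a different place, the saturated chain carbon bound to the carbonyl carbon, so it does not bear on this change directly, and no measured pair tests a substituent on the ring nitrogen. With nothing to lean on, the expectation for this assay is a step no larger than the scatter, in either direction. Compound 3 is therefore estimated at 70 ug/mL, within 30 ug/mL to 160 ug/mL, meaning an expected 1.1-fold lower number from compound 2 to compound 3 (0.06 log units; within the scatter).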

Compound 3, half-maximal inhibitory concentration: 80 ug/mL
For compound 3 the middle estimate is 1.1-fold (0.06 log units) below the measured one, within the range that was stated.
By their numbers in this assay, from the lowest: compound 1; then compounds 2 and 3 (each within the scatter of the next).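

In this assay the amine nitrogen in a ring now has a measured substituent step, and it reads no change at the digits printed from compound 2 to compound 3 (within the scatter) for 2-(dimethylamino)ethenyl in place of ethyl, so at this position the larger group with its double bond leaves the number where it stood. The other change, at the saturated chain carbon bound to a carbonyl carbon, reads a 3.7-fold higher number from compound 1 to compound 3 (0.57 log units; beyond the scatter) and matches in size a 3.7-fold higher number from compound 1 to compound 2 (0.57 log units; beyond the scatter) so the gap to compound 1 holds with either substituent on the ring nitrogen. Nothing on hand explains why this position gives no step.

Going by these compounds, two substituents on one ring nitrogen define no trend, so a carboxylic acid or a primary amine on a longer chain at that nitrogen remains open. Also open, on these data alone, is whether replacing the piperazine with a morpholine would alter the number.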